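This account rests on a few compounds, and the source may have more. Where it says the series, first, only, none or still open, it means among the compounds named here.

Compound 1 `CCOC(=O)c1ccc(-c2nn(CC)c3ccccc23)cc1` is one of the two measured compounds. In a functional assay on cells (Platelet, Homo sapiens) for inhibition (on this read-out lower numbers stand for stronger inhibition and higher numbers for weaker inhibition), compound 1 gives 360 nM. Compound 2 `O=C(O)c1ccc(-c2nn(Cc3ccccc3)c3ccccc23)cc1` is the other. In this assay compound 2 gives only > 10000 nM, which is a limit of the assay and not a number.

Compound 2 therefore stands at the weak end of what has been seen: the limit of > 10000 nM in this assay, at which 1 of the 2 values shown sits. Among the compounds with values here, nothing more than this bound is known of it, so the distance from compound 2 to compound 1 cannot be stated as a number; the two values show only that compound 1 is measurable and compound 2 is not.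

Compound 3 `CCOC(=O)/C=C/c1ccc(-c2nn(Cc3ccccc3)c3ccccc23)cc1` is the compound that has not yet been measured. Its difference from compound 2 is 2-(ethoxycarbonyl)ethenyl in place of carboxy on an aromatic carbon. Within the data shown here, no step between measured compounds connects a carboxy group to an ester, so no measured step can be pointed to. What can be said is that compound 1, which carries an ethyl ester, is the compound with a number, 360 nM. Compound 2, with its carboxy group, sits at the limit of the assay.

Compound 3 is expected to move back into the measurable range, with the step of an at least 16-fold lower number from compound 2 to compound 3 (1.22 log units; beyond the scatter) estimated to be a large one toward stronger inhibition. For compound 3 the estimate is 600 nM, with a range from 100 nM to 5000 nM.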

Compound 3, half-maximal inhibitory concentration: > 10000 nM
Compound 3: only a limit was reported; the forecaster's own chance of this, stated with the estimate: 15%; at least 16-fold (1.22 log units) between middle value and limit.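

In this assay compound 3 gives > 10000 nM, which is a limit of the assay and not a number. Compound 2 stands at the same kind of limit, so no step can be read between compound 2 and compound 3: the limit of > 10000 nM in this assay, at which 2 of the 3 values shown sit. The compounds shown leave open how strongly compound 2 and compound 3 inhibit, and whether 2-(ethoxycarbonyl)ethenyl in place of carboxy changes inhibition at all.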